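Swapping 4-methoxyphenyl for 1-methyl-1H-indazol-6-yl

The source may hold more compounds than are shown below. What is called first, only, known or untested is meant among the compounds shown, and "the series" means these compounds.

In a functional assay on B16-F0 cells (Mus musculus) for inhibition, read by CCK-8 assay, with a stated time of 48 h (on this read-out higher numbers stand for weaker inhibition and lower numbers for stronger inhibition), compound 1 (`C=Cc1ccc(-c2cc3nccc(-c4cc(OC)c(OC)c(OC)c4)n3n2)cc1`) gives 788 nM and compound 2 (`COc1ccc(-c2cc3nccc(-c4cc(OC)c(OC)c(OC)c4)n3n2)cc1`) gives 1410 nM, two numbers within the scatter of each other. Compound 3 (`COc1cc(-c2ccnc3cc(-c4ccc5cnn(C)c5c4)nn23)cc(OC)c1OC`) carries 1-methyl-1H-indazol-6-yl in place of 4-methoxyphenyl on an aromatic carbon. Among the compounds with values here, the only measured step, a 1.8-fold higher number from compound 1 to compound 2 (0.25 log units; within the scatter), exchanges a single group on the phenyl ring and offers weak guidance, since no measured compound has a fused group at this place. A tentative move to a lower number is expected, as a 4.7-fold lower number from compound 2 to compound 3 (0.67 log units; beyond the scatter). For compound 3 the estimated value is 300 nM, with an expected range of 40 nM to 1500 nM.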

Compound 3, half-maximal inhibitory concentration: 1000 nM
Compound 3: middle estimate off by 3.3-fold (0.52 log units), on the low side, and the stated range covers the measured number.
By their numbers in this assay, from the lowest: compounds 1, 3 and 2 (each within the scatter of the next).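

In this assay the fused 1-methyl-1H-indazol-6-yl group gives a 1.4-fold lower number from compound 2 to compound 3 (0.15 log units; within the scatter) and a 1.3-fold higher number from compound 1 to compound 3 (0.10 log units; within the scatter) when it replaces the substituted phenyl groups. This aromatic carbon therefore carries a fused two-ring group as well as a single phenyl ring, and the read-out does not separate the three groups shown. No evidence bears on this result.

Open, going by these compounds, is whether any group here can move the number beyond the scatter. An amine or a carboxylic acid on the aryl ring, or a longer chain in place of the indazole methyl, would test that.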